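A few compounds are considered here, and "the series" means these few. Any claim that something is new, unique, unknown or untested is made for them only; others in the source may bear on it.

Measured so far in a functional assay on KB cells (Homo sapiens) for inhibition; on this read-out lower numbers stand for stronger inhibition and higher numbers for weaker inhibition:
- Compound 1 `OCC(CO)OCn1c(Cl)nc2cc(Cl)c(Cl)cc21`: > 100000 nM, a limit
- Compound 2 `OCC(CO)OCn1c(Cl)nc2c(Cl)c(Cl)ccc21`: > 100000 nM, a limit
- Compound 3 `CNc1nc2cc(Cl)c(Cl)cc2n1COC(CO)CO`: > 100000 nM, a limit

Compound 2 has no numerical value, only the limit given above. The same holds across the series: the limit of > 100000 nM in this assay, at which 3 of the 3 values shown sit. Compound 4 `OCC(CO)OCn1c(S)nc2c(Cl)c(Cl)ccc21` differs from compound 2 at one place, with sulfanyl in place of chloro on an aromatic carbon, between two ring nitrogen atoms: sulfanyl in place of chloro on an aromatic carbon.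

Among the compounds with values here, the one measured step that also replaces this chloro is a step that the two limits leave unreadable from compound 1 to compound 3, with methylamino entering rather than sulfanyl. It was taken on compound 1, not on compound 2, and it gives neither a size nor a direction. Within the data shown here, the data therefore support no firm step in this assay, and the expectation rests on the shared limit of all three compounds. The expected change is a number no higher from compound 2 to compound 4 (the limit leaves the size open), an estimate that carries wide uncertainty. Compound 4 is estimated at 100000 nM, with an expected range of 30000 nM to 200000 nM.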

Compound 4, half-maximal inhibitory concentration: > 100000 nM
Compound 4 gave a limit, no number; the forecaster's own chance of this, stated with the estimate: 75%; the middle value lies on the limit itself.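

Compound 2 and compound 4 each give only a limit in this assay, so the step between them cannot be read. The compounds shown leave open how strongly any of them inhibits in this assay, and whether replacing this chloro changes that at all.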